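A few compounds are considered here, and "the series" means these few. Any claim that something is new, unique, unknown or untested is made for them only; others in the source may bear on it.

Of the compounds shown here, three built on one shared core have been tested in a functional assay on MCF7 cells (Homo sapiens) for cytotoxicity, read by MTT assay, with a stated time of 72 h; on this read-out lower numbers stand for stronger inhibition and higher numbers for weaker inhibition. In this assay compound 1 `COc1ccc(/C(=C(/CCCl)c2ccccc2)c2ccccc2)cc1` gives > 50000 nM, which is a limit of the assay and not a number. Compound 1 thus sits at the limit of > 50000 nM in this assay, at which 1 of the 3 values shown sits. In this assay compound 2 `COc1ccc(/C(=C(/CCN=[N+]=[N-])c2ccccc2)c2ccccc2)cc1` is recorded as "not active" (no number reported), with no number behind it. In this assay compound 3 `COc1ccc(/C(=C(/CCNC(=O)Oc2ccccc2)c2ccccc2)c2ccccc2)cc1` is likewise recorded as "not active" (no number reported), again without a number. Compound 3 therefore stands among entries that carry no single number: one further value is a limit and one further entry has no number at all, so no ranking among the three can be drawn. Compound 4 `COc1ccc(/C(=C(/CCNC(=O)N2CCCC2)c2ccccc2)c2ccccc2)cc1` differs from compound 3 in one place: pyrrolidin-1-yl in place of phenoxy on a carbonyl carbon. No step between measured compounds is shown, so the size of this change cannot be read from the numbers; with every measured compound inactive or at the limit, no movement beyond the usual scatter is expected for compound 4. Compound 4 is expected to give about 60000 nM in this assay, with a range from 20000 nM to 200000 nM.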

Compound 4, half-maximal inhibitory concentration: > 50000 nM
Compound 4 was reported as a limit; the forecaster's own chance of this, stated with the estimate: 80%; the middle value lies beyond the limit too.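

Among the compounds shown here, compound 1 and compound 4 are both reported only as limits in this assay and no step between them can be read, as both sit at the same limit: the limit of > 50000 nM in this assay, at which 2 of the 4 values shown sit. The compounds shown leave open which change on the shared core, if any, would give a measurable value.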